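Oxolan-3-yl in place of 1-hydroxy-1-methylethyl

This account rests on a few compounds, and the source may have more. Where it says the series, first, only, none or still open, it means among the compounds named here.

In an ADME assay on microsomes from liver (Rattus norvegicus) for metabolic stability, with a stated time of 60 min, tested at 1 uM (a higher number here means that more of the compound is left, a lower number that less of the compound is left), compound 2 `COc1cc(-c2cnn3cc(OC)c(C(C)(C)O)nc23)ccn1` gives 92%, the higher of the two numbers, while compound 1 `COc1cc(-c2cnn3cc(OC)c(C(C)C)nc23)ccn1` gives 14%. Compound 3 `COc1cc(-c2cnn3cc(OC)c(C4CCOC4)nc23)ccn1` carries oxolan-3-yl in place of 1-hydroxy-1-methylethyl on an aromatic carbon. Within the data shown here, the one measured step that bears on this is a number 78 percentage points higher from compound 1 to compound 2 (beyond the scatter), which is large and beyond the scatter, but it covers only hydroxy in place of hydrogen. Among the measured compounds shown here, no oxolan-3-yl compound has been measured, so the reading across is loose. A clear drop in this assay is expected, with an estimated step of a number 42 percentage points lower from compound 2 to compound 3 (beyond the scatter). The estimate for compound 3 is 50%, with a range of 25% to 78%.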

Compound 3, percent of the compound remaining: 34%
For compound 3 the middle estimate is 16 percentage points above the measured one; low and high end bracket the measured number.
By their numbers in this assay, from the lowest: compound 1; then compound 3; then compound 2.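

At this place on an aromatic carbon, the read-out in this assay does not turn on the hydroxy alone: oxolan-3-yl in place of 1-hydroxy-1-methylethyl gives a number 58 percentage points lower from compound 2 to compound 3 (beyond the scatter) and oxolan-3-yl in place of isopropyl gives a number 20 percentage points higher from compound 1 to compound 3 (beyond the scatter). Among these compounds, a group with 0 hydrogen-bond donors thus stands clear of isopropyl, yet well short of 1-hydroxy-1-methylethyl. No measurement bears on the cause of either step.

On these data alone, whether the gain over isopropyl follows the ring oxygen or the ring itself stays open, and a cyclopentyl group would separate the two. As far as these compounds go, how an amine or a 1-methoxy-1-methylethyl group would read at this place also stays open.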